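From oxan-4-yl to (oxolan-3-yl)methyl on the aromatic nitrogen

The source may hold more compounds than are shown below. What is called first, only, known or untested is meant among the compounds shown, and "the series" means these compounds.

Of the compounds shown here, three with a shared core have been measured in a functional assay on HT-29 cells (Homo sapiens) for inhibition, read by luminescence and CellTiter-Glo, with a stated time of 24 h (on this read-out lower numbers stand for an effect already at smaller amounts and higher numbers for an effect only at larger amounts of compound), and they differ only in the group on an aromatic nitrogen. Compound 1 `CN1C(=S)[C@@H](NC(=O)c2nc(Cc3ccccc3)n(CCCF)n2)COc2ccccc21`, with 3-fluoropropyl, gives 4760 nM. Compound 2 `CN1C(=S)[C@@H](NC(=O)c2nc(Cc3ccccc3)n(C3CCCCCC3)n2)COc2ccccc21`, with cycloheptyl, gives 5530 nM. Compound 3 `CN1C(=S)[C@@H](NC(=O)c2nc(Cc3ccccc3)n(C3CCOCC3)n2)COc2ccccc21`, with oxan-4-yl, gives 2260 nM, the lowest of the three numbers.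

Compound 4 `CN1C(=S)[C@@H](NC(=O)c2nc(Cc3ccccc3)n(CC3CCOC3)n2)COc2ccccc21` carries (oxolan-3-yl)methyl in place of oxan-4-yl on the same aromatic nitrogen: (oxolan-3-yl)methyl in place of oxan-4-yl on an aromatic nitrogen.

Going by the values given here, no measured pair exchanges these two groups directly. The nearest guides are the steps at this nitrogen: a 2.1-fold lower number from compound 1 to compound 3 (0.32 log units; beyond the scatter) and a 2.4-fold lower number from compound 2 to compound 3 (0.39 log units; beyond the scatter), both modest, and a 1.2-fold higher number from compound 1 to compound 2 (0.07 log units; within the scatter), within the scatter. Changes at this position have therefore stayed small so far. Compound 3 holds the lowest number, so a small move upward is expected, possibly not beyond the scatter. The expected step is a 1.4-fold higher number from compound 3 to compound 4 (0.14 log units; within the scatter). For compound 4 the estimated value is 3100 nM, within an expected range of 1500 nM to 6000 nM.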

Compound 4, half-maximal effective concentration: 4420 nM
Estimate against measurement, compound 4: 1.4-fold (0.15 log units) below; the measured number falls inside the stated range.
By their numbers in this assay, from the lowest: compounds 3, 4, 1 and 2 (each within the scatter of the next, the first and the last beyond it).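

In this assay, the same atoms rearranged from oxan-4-yl to (oxolan-3-yl)methyl give a 2.0-fold higher number from compound 3 to compound 4 (0.29 log units; within the scatter), so this change on the aromatic nitrogen cannot be told from no change. Compound 4 also stays unresolved from the groups without a ring oxygen, with a 1.3-fold lower number from compound 2 to compound 4 (0.10 log units; within the scatter) and a 1.1-fold lower number from compound 1 to compound 4 (0.03 log units; within the scatter). A ring oxygen alone is therefore not enough to separate a compound from compounds 1 and 2: among the two oxygen-bearing rings shown, only oxan-4-yl in compound 3 does so, and compound 4 goes against any rule based on the oxygen alone.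

No evidence in hand accounts for these numbers. Still open, on these data alone, are whether ring size, the methyl link or the oxygen placement matters here, and how a piperidin-4-yl amine or a carboxylic acid on this nitrogen would read.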